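Swapping the Aryl Cap on a Cinnamide Benzophenone

The source may hold more compounds than are shown below. What is called first, only, known or untested is meant among the compounds shown, and "the series" means these compounds.

Compound 1, `C#CCOc1cccc(/C=C/C(=O)Nc2cc(C(=O)c3cc(OC)c(OC)c(OC)c3)ccc2OC)c1`: 15300 nM in a functional assay on ME-180 cells (Homo sapiens) for cytotoxicity, read by MTT assay, with a stated time of 72 h; a lower number here means a stronger inhibitor, a higher number a weaker inhibitor
Compound 2, `COc1ccc(/C=C/C(=O)Nc2cc(C(=O)c3cc(OC)c(OC)c(OC)c3)cc(OC)c2OC)cc1OC`: 6700 nM in this assay

Of the two measured compounds, compound 2 has the lower number in this assay, and its nearest neighbour, compound 1, sits beyond the usual scatter above it. Compound 3, `COc1cc(C(=O)c2cc(OC)c(OC)c(OC)c2)cc(NC(=O)/C=C/c2ccc(F)cc2)c1OC`, keeps the shared core of compound 2 and changes only the aryl group at the end of the unsaturated chain: 4-fluorophenyl in place of 3,4-dimethoxyphenyl on a double-bonded chain carbon bound to a double-bonded chain carbon. Going by the values given here, no pair of measured compounds differs in exactly one place, so there is no measured step to lean on for this change. The expectation is for a modest step from compound 2 to compound 3 in this assay, most likely toward a somewhat higher number, though a result within the scatter would not surprise: a 1.3-fold higher number from compound 2 to compound 3 (0.13 log units; within the scatter). Compound 3 is therefore estimated at 9000 nM, with a plausible range from 3000 nM to 30000 nM.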

Compound 3, half-maximal inhibitory concentration: 1000 nM
Compound 3: the middle estimate sits 9.0-fold (0.95 log units) above what was measured; measured number outside the range, below it.
By their numbers in this assay, from the lowest: compound 3; then compound 2; then compound 1.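

The aryl group at the end of the unsaturated chain matters strongly in this assay (in this pair, a 6.7-fold lower number from compound 2 to compound 3 (0.83 log units; beyond the scatter)). Going by these compounds alone, this is the first measured step at this position, and it shows that the shared core does not set the number by itself. It also shows that a 3,4-dimethoxyphenyl group is not needed here, since the smaller 4-fluorophenyl group gives the lower number, but no measurement bears on what lies behind the change.

This single step cannot separate the effect of adding the fluorine from that of losing the two methoxy groups, and a plain phenyl group would help to tell them apart. Going by these compounds, how a 4-chlorophenyl group, a 4-aminophenyl group or a 4-carboxyphenyl group would compare at this position also remains open.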